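Azetidine amide in place of ethylamide: expected inhibition

This account rests on a few compounds, and the source may have more. Where it says the series, first, only, none or still open, it means among the compounds named here.

Measured so far:
compound 1 `CCNC(=O)/C=C1\CCc2ccc(F)cc21` — 100%
compound 2 `CCNC(=O)/C=C1\CCc2c(F)cc(F)cc21` — 67%

Going by the values given here, in a functional assay on the whole organism with Mus musculus as the target, at a dose of 100 mg/kg by the intraperitoneal route (on this read-out lower numbers stand for less inhibition and higher numbers for more inhibition at the one dose given (going by the name of the read-out)), compound 1 gives 100%, the highest of the two numbers; the only measured step, a number 33 percentage points lower from compound 1 to compound 2 (beyond the scatter), lies beyond the scatter. Compound 3 `O=C(/C=C1\CCc2ccc(F)cc21)N1CCC1` is not yet measured. It differs from compound 1 by azetidin-1-yl in place of ethylamino on a carbonyl carbon. Among the compounds with values here, the one measured step concerns fluoro on an aromatic carbon and does not bear on a change at the carbonyl carbon, so no measured step informs this change. Compound 3 is expected to give 70%, within 30% to 100%. The expected step of a number 30 percentage points lower from compound 1 to compound 3 (beyond the scatter) is an estimate made without any bearing step.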

Compound 3, a percentage reported as inhibition, in the whole organism at one dose (the size of the read-out at that dose, not a potency): 33%
Compound 3: middle estimate off by 37 percentage points, on the high side; the measured number falls inside the stated range.
By their numbers in this assay, from the lowest: compound 3; then compound 2; then compound 1.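

In this assay the change on the carbonyl carbon gives a number 67 percentage points lower from compound 1 to compound 3 (beyond the scatter) and so shows that the read-out responds to this position, which the earlier pair did not touch. Azetidin-1-yl in place of ethylamino removes the amide hydrogen and adds a four-membered ring in one step, so the two changes cannot be separated here. No measurement available here accounts for the drop.

The compounds shown leave open whether the ring or the lost amide hydrogen matters more, which dimethylamino or propylamino on the same carbonyl carbon would help separate. They also leave open how larger rings such as pyrrolidin-1-yl would read out.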